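Methyl in Place of Hydrogen: From Compound 1 to Compound 4

This account rests on a few compounds, and the source may have more. Where it says the series, first, only, none or still open, it means among the compounds named here.

Measured so far:
compound 1, `COc1cccc(-c2n[nH]c(-c3cccc(C)c3)n2)c1`, 15 mg/kg in this whole-animal dose assay
compound 2, `CCCCc1ccccc1-c1n[nH]c(-c2ccccc2)n1`, 17 mg/kg
compound 3, `COc1ccc(C)c(-c2n[nH]c(-c3ccccc3)n2)c1`, > 10 mg/kg, a limit of the assay rather than a number

In a functional assay on the whole organism (Cricetulus griseus) with Cricetinae gen. sp. as the target (on this read-out higher numbers stand for an effect only at larger amounts of compound and lower numbers for an effect already at smaller amounts), compound 1 gives 15 mg/kg, the lowest of the two numbers shown. Compound 2 gives 17 mg/kg, which lies within the scatter of the value of compound 1, so no order can be read between them. Compound 3 reaches only (the limit of > 10 mg/kg in this assay, at which 1 of the 3 values shown sits). Compound 4, `COc1cccc(-c2n[nH]c(-c3cc(C)ccc3C)n2)c1`, differs from compound 1 by methyl in place of hydrogen on an aromatic carbon. Within the data shown here, no step between measured compounds is available to guide this change, so the step from compound 1 to compound 4 in this assay is expected to stay within the scatter; the expected step is no change at the digits printed from compound 1 to compound 4 (within the scatter). Compound 4 is estimated at 15 mg/kg, between 7 mg/kg and 32 mg/kg.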

Compound 4, dose for half-maximal effect: 2.5 mg/kg
For compound 4 the middle estimate is 6.0-fold (0.78 log units) above the measured one; measured number outside the range, below it.
By their numbers in this assay, from the lowest: compound 4; then compounds 1 and 2 (each within the scatter of the next).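

Methyl in place of hydrogen on an aromatic carbon, ortho to a large group and para to a methyl group, gives a 6.0-fold lower number from compound 1 to compound 4 (0.78 log units; beyond the scatter) in this assay. This is the only change at a single place among the compounds shown, and it indicates that this position responds to one added carbon. Nothing shown gives a reason for the step. The compounds leave open whether ethyl, methoxy or chlorine on this same carbon would give a similar number. They also leave open whether the number of compound 4 depends on the methyl group para to this position.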